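Aryl swap on the triazole of a spirooxindole series

The source may hold more compounds than are shown below. What is called first, only, known or untested is meant among the compounds shown, and "the series" means these compounds.

Compound 1 `N#CC1=C(N)Oc2c(c3nc4ccccc4nc3c3ccccc23)C12C(=O)N(Cc1cnnn1-c1ccc(Cl)cc1)c1ccccc12`: > 50000 nM in a functional assay on A549 cells (Homo sapiens) for antiproliferative activity, read by MTT assay, with a stated time of 48 h; on this read-out lower numbers stand for stronger inhibition and higher numbers for weaker inhibition; this is a limit of the assay.
Compound 2 `N#CC1=C(N)Oc2c(c3nc4ccccc4nc3c3ccccc23)C12C(=O)N(Cc1cnnn1-c1ccc(Br)cc1)c1ccccc12`: 44300 nM in this assay.
Compound 3 `N#CC1=C(N)Oc2c(c3nc4ccccc4nc3c3ccccc23)C12C(=O)N(Cc1cnnn1-c1ccc([N+](=O)[O-])cc1)c1ccccc12`: > 50000 nM in this assay; this is a limit of the assay.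

Compound 3 stands at the limit, the value at which (the limit of > 50000 nM in this assay, at which 2 of the 3 values shown sit); no number beyond that limit is known for it. Compound 4 `Cc1ccc(-n2nncc2CN2C(=O)C3(C(C#N)=C(N)Oc4c3c3nc5ccccc5nc3c3ccccc43)c3ccccc32)cc1Cl` has not yet been measured in this assay. It differs from compound 3 as follows: 3-chloro-4-methylphenyl in place of 4-nitrophenyl on an aromatic nitrogen.

Within the data shown here, three measured steps bear on this change, all of them swaps of the group on the same aromatic carbon of the phenyl ring. The step of an at least 1.1-fold lower number from compound 1 to compound 2 (0.05 log units; that floor lies within the scatter) is bromo in place of chloro. The step that the two limits leave unreadable from compound 1 to compound 3 is nitro in place of chloro. The step of an at least 1.1-fold higher number from compound 2 to compound 3 (0.05 log units; that floor lies within the scatter) is nitro in place of bromo. None of these steps rises above the scatter, and two of the three compounds sit at the limit. The chloro-bearing compound 1 and the nitro-bearing compound 3 therefore give no numbers to move from, and the bromo-bearing compound 2 gives a number close to the limit.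

Compound 4 is therefore expected to remain near the limit, a step of an at least 1.1-fold lower number from compound 3 to compound 4 (0.04 log units; that floor lies within the scatter) that is not expected to pass the scatter. For compound 4 the estimate in this assay is 45000 nM, with a range from 15000 nM to 50000 nM.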

Compound 4, half-maximal inhibitory concentration: > 50000 nM
Compound 4 was reported as a limit (the forecaster's own chance of this, stated with the estimate: 60%); middle value at least 1.1-fold (0.04 log units) away from the limit.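

In this assay compound 4 gives > 50000 nM, which is a limit of the assay and not a number. Among these compounds, the one step that can be read is an at least 1.1-fold higher number from compound 2 to compound 4 (0.05 log units; that floor lies within the scatter), while the steps from compound 1 and from compound 3 to compound 4 join two limits and cannot be read. What compound 4 adds is that a phenyl ring carrying both a chloro and a methyl group, as 3-chloro-4-methylphenyl on the aromatic nitrogen, does not bring the series clear of the limit, so the picture at this position is unchanged and now rests on one more aryl group: the limit of > 50000 nM in this assay, at which 3 of the 4 values shown sit.

Every compound shown keeps a phenyl ring bearing chloro, bromo, nitro or methyl on this nitrogen, so it stays open whether a methoxy group, an amine or a carboxylic acid on that ring, or a longer alkyl chain in place of the ring, would give a number well clear of the limit. As far as these compounds go, it also stays open whether any change to the shared core, rather than to this aryl group, would do so.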